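The source may hold more compounds than are shown below. What is called first, only, known or untested is meant among the compounds shown, and "the series" means these compounds.

Measured so far:

Compound 1, `COc1cc(C(=O)O)ccc1OCc1nc(C)c(C)nc1C`: 19%

Compound 2, `Cc1nc(C)c(CSc2nnc(-c3cccs3)n2N)nc1C`: 40.2%

Both compounds were tested in a functional assay on ECV-304 cells (Homo sapiens), read by MTT assay, with stated times of 24 h and 12 h, tested at 100 uM; on this read-out lower numbers stand for a weaker effect and higher numbers for a stronger effect at the one concentration tested. Among the measured compounds shown here, of the two numbers, compound 2 stands highest; its only neighbour, compound 1, gives a number lower by a margin beyond the usual scatter of this assay. The two compounds share nothing but a common small ring, so their gap cannot be tied to any single change in structure.

The next compound, compound 3, `Cc1nc(C)c(CSc2nnc(-c3ccco3)n2N)nc1C`, differs from compound 2 in exactly one place: furan-2-yl in place of thiophen-2-yl on an aromatic carbon. For the measured compounds named here, no pair of measured compounds shows what this kind of exchange does to the read-out, so there is no measured step to lean on. The group that leaves and the group that enters are alike in size and in the number of donors and acceptors, and the swap of one five-membered ring for another of the same shape is among the smallest changes a molecule can undergo. The step from compound 2 to compound 3 is therefore expected to be small, most likely none beyond the scatter, with a slight lean downward: a number 4.2 percentage points lower from compound 2 to compound 3 (within the scatter). Compound 3 is expected to give 36% in this assay, within a range from 20% to 52%.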

Compound 3, a percentage reported as activity, at one concentration (the size of the read-out at that concentration, not a potency): 25.8%
For compound 3 the middle estimate is 10.2 percentage points above the measured one, within the range that was stated.
By their numbers in this assay, from the lowest: compounds 1 and 3 (each within the scatter of the next); then compound 2.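

Placing furan-2-yl in place of thiophen-2-yl on this aromatic carbon gives, in this assay, a number 14.4 percentage points lower from compound 2 to compound 3 (beyond the scatter). Among the compounds shown here, this is the first measured step at this position, and it shows that the read-out responds to a change here even though the two groups match in heavy-atom count, ring size, hydrogen-bond donors and acceptors, and net charge. Those counts therefore do not settle the outcome at this carbon, since the ring hetero atom, sulfur in one group and oxygen in the other, is the only difference between compound 2 and compound 3, and no measurement shown here explains why this exchange lowers the number.

From the compounds shown here alone, with a single step at this position, it remains open whether the trend seen here extends to other groups on this carbon, such as a phenyl ring, a methyl group or an amine. Also open, going by these compounds, is how much the amino group on the ring atom that bears it contributes, and whether this step would hold at concentrations other than the single one tested.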